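From compound 3 to compound 4

This account rests on a few compounds, and the source may have more. Where it says the series, first, only, none or still open, it means among the compounds named here.

compound 1 `COc1ccc(/C=C\c2cc(OC)c(OC)c(OC)c2)cc1OCc1ccc(CN2C[C@H](O)C[C@@H]2C(=O)O)cc1` gives > 50000 nM as a limit of the assay
compound 2 `COc1ccc(/C=C\c2cc(OC)c(OC)c(OC)c2)cc1OCc1ccc(CO)cc1` gives 37000 nM
compound 3 `COc1ccc(/C=C\c2cc(OC)c(OC)c(OC)c2)cc1OCc1ccc(CNCCN(C)C)cc1` gives 39000 nM

Compound 3 gives 39000 nM in an ADME assay on HEK293 cells (Homo sapiens) for cytotoxicity, read by CCK-8 assay, with a stated time of 48 h (on this read-out higher numbers stand for weaker inhibition and lower numbers for stronger inhibition), and sits level with compound 2, with a 1.1-fold higher number from compound 2 to compound 3 (0.02 log units; within the scatter) inside the scatter. The change to compound 4 `COc1ccc(/C=C\c2cc(OC)c(OC)c(OC)c2)cc1OCc1ccc(CN2CC[C@@H](C(=O)O)C2)cc1` is 3-carboxypyrrolidin-1-yl in place of (2-(dimethylamino)ethyl)amino on a saturated chain carbon bound to an aromatic carbon on a saturated chain carbon bound to an aromatic carbon. Compound 1 carries 2-carboxy-4-hydroxypyrrolidin-1-yl at that place, so an at least 1.2-fold lower number from compound 1 to compound 3 (0.10 log units; that floor lies within the scatter) and an at least 1.3-fold lower number from compound 1 to compound 2 (0.13 log units; that floor lies within the scatter) bear on it, both with floors within the scatter. Compound 1 rests on the limit of > 50000 nM in this assay, at which 1 of the 3 values shown sits, as its reading. Read backwards, an at least 1.2-fold lower number from compound 1 to compound 3 (0.10 log units; that floor lies within the scatter) points to a small rise, possibly none beyond the scatter. A step of a 1.3-fold higher number from compound 3 to compound 4 (0.11 log units; within the scatter) is expected in this assay on that basis. The estimate for compound 4 is 50000 nM within an expected range of 28000 nM to 90000 nM and a report as a limit is possible.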

Compound 4, half-maximal inhibitory concentration: 27000 nM
For compound 4 the middle estimate is 1.9-fold (0.27 log units) above the measured one; the measured number lies below the stated range.
By their numbers in this assay, from the lowest: compounds 4, 2 and 3 (each within the scatter of the next). At a limit, above all of these: compound 1.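

In this assay, compound 4 gives the series a carboxylic acid reading that is not a limit, and both a 1.4-fold lower number from compound 3 to compound 4 (0.16 log units; within the scatter) and a 1.4-fold lower number from compound 2 to compound 4 (0.14 log units; within the scatter) stay inside the scatter. On a saturated chain carbon bound to an aromatic carbon, hydroxy, (2-(dimethylamino)ethyl)amino and 3-carboxypyrrolidin-1-yl therefore cannot be told apart in these readings. The step of an at least 1.8-fold lower number from compound 1 to compound 4 (0.26 log units; that floor lies within the scatter) starts from a limit of the assay, and its floor lies within the scatter: the limit of > 50000 nM in this assay, at which 1 of the 4 values shown sits.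

From the compounds shown here alone, how far 2-carboxy-4-hydroxypyrrolidin-1-yl really stands from 3-carboxypyrrolidin-1-yl remains open. Also open, going by these compounds, is what a piperidine carboxylic acid or a primary amine would give at this place.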